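Extending the Basic Side Chain of Compound 2

This account rests on a few compounds, and the source may have more. Where it says the series, first, only, none or still open, it means among the compounds named here.

Going by the values given here, compound 2 `CNCCNc1nnc(-c2ccc(F)c(F)c2Nc2ccc(I)cc2F)o1` is the only member of this set with a number in a physicochemical assay for solubility, read by HPLC, in phosphate buffer, at pH 6.5 (on this read-out lower numbers stand for lower solubility and higher numbers for higher solubility), where compound 2 gives 6.7 ug/mL. Compound 1 `OCCCNc1nnc(-c2ccc(F)c(F)c2Nc2ccc(I)cc2F)o1` gives only a limit, < 3 ug/mL. Compound 3 `OCCNc1nnc(-c2ccc(F)c(F)c2Nc2ccc(I)cc2F)o1` likewise gives only a limit, < 3 ug/mL. Compound 4 `CCN(CC)CCCNc1nnc(-c2ccc(F)c(F)c2Nc2ccc(I)cc2F)o1` differs from compound 2 by (diethylamino)methyl in place of methylamino on a saturated chain carbon, two bonds along the chain from a nitrogen on an aromatic ring. The measured steps touching the methylamino group are an at least 2.2-fold higher number from compound 1 to compound 2 (0.34 log units; beyond the scatter) and an at least 2.2-fold lower number from compound 2 to compound 3 (0.34 log units; beyond the scatter), both running into (the limit of < 3 ug/mL in this assay, at which 2 of the 3 values shown sit), so the amine-bearing compound sits higher than either alcohol. Since compound 2 gives 6.7 ug/mL with an amine nitrogen on the chain and compound 4 keeps such a nitrogen, the step is expected to be a 1.2-fold higher number from compound 2 to compound 4 (0.08 log units; within the scatter). Compound 4 is therefore estimated at 8 ug/mL, between 2.5 ug/mL and 30 ug/mL.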

Compound 4, solubility: < 3 ug/mL
Compound 4: no number, only a limit; the forecaster's own chance of this, stated with the estimate: 20%; middle value at least 2.6-fold (0.42 log units) from the limit.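

Keeping an amine nitrogen on the chain does not keep the reading of compound 2 in this assay: the change to a 3-(diethylamino)propyl chain gives an at least 2.2-fold lower number from compound 2 to compound 4 (0.34 log units; beyond the scatter), so an amine there is no guarantee of a number. Compound 4 gives only a limit, and its steps from compound 1 and compound 3 cannot be read. Compound 2 now stands alone above the floor of the set: the limit of < 3 ug/mL in this assay, at which 3 of the 4 values shown sit.

The compounds shown leave open whether the longer chain or the ethyl groups on the nitrogen account for the step. A 3-(methylamino)propyl or a 2-(diethylamino)ethyl chain would separate the two.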